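The source may hold more compounds than are shown below. What is called first, only, known or untested is meant among the compounds shown, and "the series" means these compounds.

Compound 1, `Cc1ccc(C(=O)Nc2nc(Cl)c3cn(CC(C)(C)C)nc3n2)cc1`, in a functional assay on CHO cells for antagonist activity at adenosine receptor A2b (Homo sapiens), read by 33P incorporation, with a stated time of 20 min, in the presence of a further agent that is not named here (on this read-out higher numbers stand for weaker inhibition and lower numbers for stronger inhibition), gives > 10000 nM, which is a limit of the assay and not a number.
Compound 2, `CC(C)n1cc2c(Cl)nc(NC(=O)c3ccccc3)nc2n1`, in this assay gives > 20000 nM, again a limit and not a number.
Compound 3, `CC(C)(C)Cn1cc2c(Cl)nc(NC(=O)c3ccc(C(F)(F)F)cc3)nc2n1`, in this assay gives > 20000 nM, also a limit and not a number.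

So compound 3 stands at the second of the two limits, the one described by the limit of > 20000 nM in this assay, at which 2 of the 3 values shown sit, where it sits together with compound 2; compound 1 sits at the other limit, (the limit of > 10000 nM in this assay, at which 1 of the 3 values shown sits). The only measured step among these three, a step that the two limits leave unreadable from compound 1 to compound 3, cannot be read, because both ends are limits. Compound 4, `CC(C)n1cc2c(Cl)nc(NC(=O)c3ccc(C(F)(F)F)cc3)nc2n1`, has not yet been measured in this assay. It differs from compound 3 in one place: isopropyl in place of neopentyl on an aromatic nitrogen. Among the measured compounds shown here, no measured step addresses this exchange on its own; compound 2 carries the same isopropyl group, but it also lacks the trifluoromethyl of compound 3, so its value shows only that a compound with isopropyl on that nitrogen also reached a limit. With every measured value at a limit, no direction or size of change can be drawn, and compound 4 is expected to sit at a limit as well, the step that the limit leaves unreadable from compound 3 to compound 4 being the expectation. The estimate for compound 4 in this assay is 30000 nM, between 10000 nM and 100000 nM.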

Compound 4, inhibition constant: > 20000 nM
Compound 4 ended at the assay's limit; the forecaster's own chance of this, stated with the estimate: 85%; the middle value does not contradict the limit.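

Compound 4 also ends at a limit of the assay and not a number, so neither the exchange of neopentyl for isopropyl from compound 3 nor the trifluoromethyl in place of hydrogen from compound 2 can be read as a step. The compounds shown leave open how large either exchange's effect is in this assay.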